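A Benzothiophene in Place of Methoxyphenyl on the Shared Core

This account rests on a few compounds, and the source may have more. Where it says the series, first, only, none or still open, it means among the compounds named here.

Compound 1, `COc1ccc(-c2nc(CNc3ccc(C(=O)NO)cc3)n(-c3ccccc3)n2)cc1`: 163 nM
Compound 2, `COc1ccc(-n2nc(-c3ccc(O)cc3)nc2CNc2ccc(C(=O)NO)cc2)cc1`: 102 nM
Compound 3, `O=C(NO)c1ccc(NCc2nc(-c3ccccc3)nn2-c2ccc(Br)cc2)cc1`: 1730 nM

All three were measured in an assay on Sf9 cells for inhibition of protein deacetylase HDAC6 (Homo sapiens), read by fluorescence, with a stated time of 40 min; a lower number here means a stronger inhibitor, a higher number a weaker inhibitor. Compound 1 stands second highest of the three numbers; compound 2 lies within the scatter of it, while compound 3 sits beyond the scatter with the higher number. Compound 4, `O=C(NO)c1ccc(NCc2nc(-c3cc4ccccc4s3)nn2-c2ccccc2)cc1`, has not yet been measured in this assay. It differs from compound 1 by 1-benzothiophen-2-yl in place of 4-methoxyphenyl on an aromatic carbon. Within the data shown here, no step between two measured compounds that differ in one place is available, so the expectation rests on compound 1 alone. The expected step is a 1.5-fold higher number from compound 1 to compound 4 (0.19 log units; within the scatter), modest and, if anything, toward a higher number. For compound 4 the estimated value is 250 nM, with a range from 80 nM to 800 nM.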

Compound 4, half-maximal inhibitory concentration: 324 nM
Compound 4: middle estimate off by 1.3-fold (0.11 log units), on the low side; low and high end bracket the measured number.
By their numbers in this assay, from the lowest: compounds 2, 1 and 4 (each within the scatter of the next, the first and the last beyond it); then compound 3.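

In this assay, among these compounds, this is the first direct reading at the aromatic carbon between two ring nitrogen atoms: 1-benzothiophen-2-yl in place of 4-methoxyphenyl gives a 2.0-fold higher number from compound 1 to compound 4 (0.30 log units; within the scatter) on the shared core. The position therefore takes a group with one five-membered and one six-membered aromatic ring, sulfur entering and oxygen leaving, without a step beyond the scatter. Nothing available explains why the two groups read alike.

From the compounds shown here alone, what a carboxylic acid, a morpholine or a simple methyl group would give at this carbon remains open.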